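The compounds below may be only part of what the source reports. "The series", "measured", "known", "first", "only" and "open" are said of these compounds alone.

Working notes on a small set sharing one core that carries an acetyl group and a 4-fluorophenyl group. Compound 1 `CC(=O)c1cc(-c2ccccc2)cc2cc(-c3ccc(F)cc3)[nH]c12` gives 98.5% in a functional assay on MCF7 cells (Homo sapiens) for cytotoxicity, read by MTT assay, with a stated time of 2 days, tested at 0.1 uM; a lower number here means a stronger effect, a higher number a weaker effect of the compound at the concentration tested. Compound 2 `CC(=O)c1cc(-c2ccc(F)cc2)cc2cc(-c3ccc(F)cc3)[nH]c12` gives 99.8% in this assay; the change is fluoro in place of hydrogen on an aromatic carbon and the step is a number 1.3 percentage points higher from compound 1 to compound 2 (within the scatter). Compound 3 `CC(=O)c1cc(/C=C/c2ccccc2)cc2cc(-c3ccc(F)cc3)[nH]c12` differs from compound 1 by 2-phenylethenyl in place of phenyl on an aromatic carbon. In this assay compound 3 gives 98.4%; the step is a number 0.1 percentage points lower from compound 1 to compound 3 (within the scatter), and the step between the other two is a number 1.4 percentage points lower from compound 2 to compound 3 (within the scatter). All three numbers sit within the scatter of one another, so no order among them is drawn.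

Compound 4 `CC(=O)c1cc(/C=C/c2ccc(F)cc2)cc2cc(-c3ccc(F)cc3)[nH]c12` is not yet measured. It differs from compound 3 by fluoro in place of hydrogen on an aromatic carbon, the same kind of change as that between compound 1 and compound 2, at a place that in both cases is para to a large group, though on cores that differ as already noted. The step from compound 3 to compound 4 in this assay is expected to be a number 0.6 percentage points higher from compound 3 to compound 4 (within the scatter), because the same change gave a number 1.3 percentage points higher from compound 1 to compound 2 (within the scatter). Compound 4 is therefore estimated at 99% in this assay, with an expected range from 94% to 103%.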

Compound 4, a percentage reported as activity, at one concentration (the size of the read-out at that concentration, not a potency): 98.8%
The estimate for compound 4 lay 0.2 percentage points above the measured number, and the stated range covers the measured number.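

In this assay the fluoro change on the 2-phenylethenyl group gives a number 0.4 percentage points higher from compound 3 to compound 4 (within the scatter), and this agrees with the same change on the phenyl group of the core of compound 1: the same change on two cores in this assay, a number 1.3 percentage points higher (within the scatter) from compound 1 to compound 2 and a number 0.4 percentage points higher (within the scatter) from compound 3 to compound 4, 0.9 percentage points apart, within the scatter of two such steps. The other two new steps, a number 1 percentage points lower from compound 2 to compound 4 (within the scatter) and a number 0.3 percentage points higher from compound 1 to compound 4 (within the scatter), are also small, so all four compounds lie within the scatter of one another at this single concentration. The change therefore carries across these two cores without a detectable difference, but every step is too small to show that it has any effect on either core, so this agreement says nothing about how it would carry over in compounds with a stronger effect.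

Still open, from the compounds shown here alone, is how an amine or a carboxylic acid in place of the fluoro would read in this assay. Also open, going by these compounds, is whether a longer chain in place of the acetyl group would move the number beyond the scatter.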